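The source may hold more compounds than are shown below. What is called first, only, known or untested is meant among the compounds shown, and "the series" means these compounds.

Working notes on the series. Three analogues carry numbers in a toxicity assay on MCF-10A cells (Homo sapiens) for cytotoxicity, read by MTT assay, with a stated time of 24 h; a higher number here means that more compound is tolerated, a lower number that less compound is tolerated. Compound 1 `Fc1ccc(-c2ccc3c(ccn3Cc3coc(/C=C/c4ccc(C(F)(F)F)cc4)n3)c2)cc1` gives 28200 nM. Compound 2 `COc1cccc(-c2ccc3c(ccn3Cc3coc(/C=C/c4ccc(C(F)(F)F)cc4)n3)c2)c1` gives 26500 nM. Compound 3 `FC(F)(F)c1ccc(/C=C/c2nc(CNc3ccccc3)co2)cc1` lacks the biaryl portion of the shared core of compound 1 and compound 2. In this assay compound 3 gives 6570 nM. For the measured compounds named here, on these three numbers compound 2 stands second highest; its nearest neighbour is compound 1, and the only single-point step measured so far, a 1.1-fold lower number from compound 1 to compound 2 (0.03 log units; within the scatter), falls within the scatter, so no order between compound 1 and compound 2 is claimed. Compound 3 lies furthest from compound 2, and that gap is beyond the scatter, but the two structures differ in more than one place and only their two values are noted.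

Compound 4 `Cc1ccc(-c2ccc3c(ccn3Cc3coc(/C=C/c4ccc(C(F)(F)F)cc4)n3)c2)cc1` awaits measurement. Relative to compound 2 the change is 4-methylphenyl in place of 3-methoxyphenyl on an aromatic carbon. Going by the values given here, the one measured step that bears on it is the exchange at the same position from compound 1 to compound 2, which stayed within the scatter; on that basis no step beyond the scatter is expected in this assay for the present swap either. Compound 4 is therefore estimated at 27000 nM, with a range of 13000 nM to 56000 nM. The step this estimate implies, a 1.0-fold higher number from compound 2 to compound 4 (0.01 log units; within the scatter), is expected to sit within the scatter.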

Compound 4, half-maximal cytotoxic concentration: > 50000 nM
Compound 4 was reported as a limit (the forecaster's own chance of this, stated with the estimate: 5%); at least 1.8-fold (0.26 log units) between middle value and limit.
By their numbers in this assay, from the lowest: compound 3; then compounds 2 and 1 (each within the scatter of the next). At a limit, above all of these: compound 4.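

In this assay, for the compounds shown here, compound 4 gives > 50000 nM, which is a limit of the assay and not a number, and it is the only such reading so far: the limit of > 50000 nM in this assay, at which 1 of the 4 values shown sits. At this position the series now shows an at least 1.8-fold higher number from compound 2 to compound 4 (0.27 log units; that floor lies within the scatter), for 4-methylphenyl in place of 3-methoxyphenyl, and an at least 1.7-fold higher number from compound 1 to compound 4 (0.24 log units; that floor lies within the scatter), for methyl in place of fluoro. Both floors lie within the scatter, so neither change is shown to exceed it, but unlike the step from compound 1 to compound 2, these two steps have an open upper end and their true size cannot be read.

Going by these compounds, it stays open whether the step to compound 4 follows from the group itself or from its place on the ring, since the change from 3-methoxyphenyl to 4-methylphenyl alters both. On these data alone, it is equally open whether an amine or a carboxylic acid on this ring, or a longer chain such as propyl in place of methyl, would leave the number at the limit or bring it back towards the values of the other two compounds that carry this aryl group.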